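The source may hold more compounds than are shown below. What is called first, only, known or untested is meant among the compounds shown, and "the series" means these compounds.

Compound 1 `COC(=O)c1ccc(NCc2cncn2Cc2cccc(Br)c2)cc1-c1ccccc1`: > 10000 nM
Compound 2 `O=[N+]([O-])c1ccc(Cn2cncc2CNc2cccc(-c3ccccc3)c2)cc1`: 10000 nM

In a toxicity assay on NIH3T3 cells (Mus musculus) for cytotoxicity, read by resazurin assay (on this read-out higher numbers stand for an effect only at larger amounts of compound and lower numbers for an effect already at smaller amounts), compound 1 gives > 10000 nM, which is a limit of the assay and not a number. Compound 2 gives 10000 nM in this assay. Among the compounds with values here, compound 1 therefore stands at the top of what the assay resolves, at the limit of > 10000 nM in this assay, at which 1 of the 2 values shown sits, and the two values show only that neither compound reaches a measurable effect within the tested range.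

Compound 3 `COC(=O)c1ccc(NCc2cncn2Cc2cccc(N)c2)cc1-c1ccccc1` has not yet been measured. It differs from compound 1 by amino in place of bromo on an aromatic carbon. Within the data shown here, no measured pair carries this change, so its size is unknown from these data. Since compound 1 sits at the limit (the limit of > 10000 nM in this assay, at which 1 of the 2 values shown sits), the step is expected to be none beyond the scatter, namely a number no higher from compound 1 to compound 3 (the limit leaves the size open). Compound 3 is estimated at 10000 nM in this assay, expected to fall between 4000 nM and 30000 nM.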

Compound 3, half-maximal effective concentration: > 10000 nM
Compound 3: only a limit was reported; the forecaster's own chance of this, stated with the estimate: 70%; the middle value sits exactly at the limit.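

In this assay compound 3 gives > 10000 nM, which is a limit of the assay and not a number. No step can be read between compound 1 and compound 3, because both carry only a limit: the limit of > 10000 nM in this assay, at which 2 of the 3 values shown sit.

The compounds shown leave open how amino and bromo on this aromatic carbon compare.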